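The source may hold more compounds than are shown below. What is called first, only, known or untested is meant among the compounds shown, and "the series" means these compounds.

Among the compounds with values here, compound 1 (`O=C(Cc1csc2nc(-c3ccc(Br)cc3)cn12)N/N=C/c1ccccc1`) gives 28200 nM in a functional assay on UACC-62 cells (Homo sapiens) for inhibition, read by sulforhodamine B assay, with a stated time of 48 h (on this read-out lower numbers stand for stronger inhibition of growth and higher numbers for weaker inhibition of growth), on the numbers so far. Compound 2 (`O=C(Cc1csc2nc(-c3ccc(Br)cc3)cn12)N/N=C/c1ccc(O)cc1`) gives 23400 nM in this assay as well. These two values lie within the scatter of each other, so compound 1 holds no clear rank yet.

Compound 3 (`O=C(Cc1csc2nc(-c3ccc(Br)cc3)cn12)N/N=C/c1ccc(Cl)cc1Cl`) is still unmeasured and departs from compound 1 as follows: 2,4-dichlorophenyl in place of phenyl on a carbon with a double bond to nitrogen. Within the data shown here, only one measured step bears on this, and only loosely: a 1.2-fold lower number from compound 1 to compound 2 (0.08 log units; within the scatter) (hydroxy in place of hydrogen on an aromatic carbon) stays within the scatter. Among the measured compounds shown here, no measured compound carries chlorine, so the data give no direct guide to the size or direction of this change.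

No shift beyond the scatter is therefore expected in this assay and the range is kept wide. The expected step is a 1.3-fold lower number from compound 1 to compound 3 (0.11 log units; within the scatter) and it remains an estimate. For compound 3 the estimated value is 22000 nM with an expected range from 9000 nM to 55000 nM in this test.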

Compound 3, concentration for total growth inhibition: 67600 nM
Beside the measured number, compound 3's estimate is 3.1-fold (0.49 log units) below it, and the stated range ends below it.
By their numbers in this assay, from the lowest: compounds 2 and 1 (each within the scatter of the next); then compound 3.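

In this assay, the position on the carbon with a double bond to nitrogen now proves able to shift the read-out: 2,4-dichlorophenyl in place of phenyl gives a 2.4-fold higher number from compound 1 to compound 3 (0.38 log units; beyond the scatter) and thus weaker inhibition of growth, whereas the earlier hydroxy step stayed within the scatter. Set against 4-hydroxyphenyl, the same group gives a 2.9-fold higher number from compound 2 to compound 3 (0.46 log units; beyond the scatter) and thus also weaker inhibition of growth, so both steps point the same way, both are modest, and compound 3 stands as the weakest of the three compounds. Nothing available here accounts for this shift.

Going by these compounds, whether a single chlorine on the phenyl ring would give the same rise as the pair remains open, as does the way the number would move with a methoxy group, an amine or a carboxylic acid on that ring. It is also open whether a change at this position could take the number clearly lower than the values of compound 1 and compound 2, since neither of the steps shown does so.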